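The source may report more compounds than this note shows. Statements on the series, on what has been measured and on what is new or still open speak of the compounds shown alone.

Measured so far in a functional assay on HEK293 cells for antagonist activity at transient receptor potential cation channel subfamily V member 1 (Homo sapiens), read by calcium flux; a lower number here means a stronger inhibitor, a higher number a weaker inhibitor: compound 1 `FC(F)(F)c1ccc(Nc2ncnc3sc(Nc4c(Cl)cccc4Cl)nc23)cc1` gives 12 nM; compound 2 `CSc1ccc(Nc2ncnc3sc(Nc4c(Cl)cccc4Cl)nc23)cc1` gives 96 nM; compound 3 `FC(F)(F)c1ccc(Nc2ncnc3sc(Nc4c(Cl)cccc4Cl)nc23)cc1Cl` gives 21 nM.

Compound 3 stands second highest of the three numbers, within the scatter of compound 1 and well apart from compound 2 (an 8.0-fold higher number from compound 1 to compound 2 (0.90 log units; beyond the scatter)). The step of a 1.8-fold higher number from compound 1 to compound 3 (0.24 log units; within the scatter) shows that adding chloro to the outer ring changed little.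

Compound 4 `CS(=O)(=O)c1nc(Nc2ccc(C(F)(F)F)c(Cl)c2)c2nc(Nc3c(Cl)cccc3Cl)sc2n1` differs from compound 3 in one place: methylsulfonyl in place of hydrogen on an aromatic carbon, sitting on the shared core between two ring nitrogen atoms. For the measured compounds named here, neither measured step touches this part of the core, so no step bears directly on it. The expectation is therefore a step of a 1.9-fold higher number from compound 3 to compound 4 (0.28 log units; within the scatter) of roughly no change beyond the scatter. Compound 4 is estimated at 40 nM in this assay, with a range from 10 nM to 160 nM.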

Compound 4, half-maximal inhibitory concentration: 274 nM
Compound 4: the middle estimate sits 6.9-fold (0.84 log units) below what was measured, and the stated range ends below it.
By their numbers in this assay, from the lowest: compounds 1 and 3 (each within the scatter of the next); then compound 2; then compound 4.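

In this assay, methylsulfonyl in place of hydrogen on the aromatic carbon between two ring nitrogen atoms gives a 13-fold higher number from compound 3 to compound 4 (1.12 log units; beyond the scatter), a large step. For the compounds shown here, this is the first sign that the shared core is sensitive to change at this position, whereas the chloro step on the outer ring stayed within the scatter. Nothing available explains why this change weakens the inhibitor. On these data alone, whether any group on this carbon has a similar effect, or only methylsulfonyl does, stays open. An amine or a methoxy group here would help to separate the two.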